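A Propoxy Variant of Compound 1 Under Test

This account rests on a few compounds, and the source may have more. Where it says the series, first, only, none or still open, it means among the compounds named here.

Measured so far in a functional assay on PC-3 cells (Homo sapiens) for inhibition, read by sulforhodamine B assay, with a stated time of 48 h, tested at 50 uM; a higher number here means more inhibition of growth at the concentration tested, a lower number less inhibition of growth:
- compound 1 `COc1cc2c(cc1CC=C(C)C)C(=O)C[C@@H](c1ccc(Oc3ccccc3)cc1)O2` gives 53%
- compound 2 `COc1ccc([C@@H]2C/C(=N/OCc3cn(-c4ccc(C#N)cc4)nn3)c3cc(CC=C(C)C)c(OC)cc3O2)cc1` gives 50%
- compound 3 `COc1ccc([C@@H]2C/C(=N/OCc3cn(-c4ccc(NC(=O)c5ccccc5)cc4)nn3)c3cc(CC=C(C)C)c(OC)cc3O2)cc1` gives 22%

Compound 1 sits at the upper end of these three numbers. Its gap to compound 2 lies within the usual scatter, so the two cannot be ranked against each other; its gap to compound 3 lies beyond the scatter. Within the data shown here, the only step between two measured compounds that differ in a single place is a number 28 percentage points lower from compound 2 to compound 3 (beyond the scatter), and that step concerns a group on a different part of the molecule than the one changed here.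

Compound 4 `CCCOc1ccc([C@@H]2CC(=O)c3cc(CC=C(C)C)c(OC)cc3O2)cc1` differs from compound 1 in one place: propyl in place of phenyl on an oxygen on an aromatic ring. Among the measured compounds shown here, no measured pair shows this change, so the data give no direct guide to its effect. With nothing pointing either way, the step from compound 1 to compound 4 is expected to stay within the scatter, estimated as a number 3 percentage points lower from compound 1 to compound 4 (within the scatter). For compound 4 the expected value in this assay is therefore 50%, with a likely range from 30% to 70%.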

Compound 4, percent growth inhibition at one concentration: 54%
For compound 4 the middle estimate is 4 percentage points below the measured one; the measured number falls inside the stated range.
By their numbers in this assay, from the lowest: compound 3; then compounds 2, 1 and 4 (each within the scatter of the next).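

In this assay, putting propyl in place of phenyl on an oxygen on an aromatic ring gives a number 1 percentage points higher from compound 1 to compound 4 (within the scatter). Among these compounds, this is the first direct look at this position, and it shows that, at the one concentration tested, the aromatic ring of the phenoxy group can give way to an open chain with no ring without a change beyond the scatter. Nothing available explains why compound 1 and compound 4 read alike.

Still open, as far as these compounds go, is how a longer chain such as hexyl, or a chain ending in an amine or a carboxylic acid, would read on the same oxygen. A reading at one concentration also cannot show whether compound 1 and compound 4 would stay alike across a range of concentrations.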